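From Hydrogen to Chloro on the Shared Core

The compounds below may be only part of what the source reports. "The series", "measured", "known", "first", "only" and "open" are said of these compounds alone.

In a functional assay on HCT-116 cells (Homo sapiens) for antiproliferative activity, read by MTT assay, with a stated time of 48 h (a higher number here means a weaker inhibitor, a lower number a stronger inhibitor), compound 1 `CCCCC(CCO)n1cnc2c(Cl)nc(Cl)nc21` gives 15500 nM and compound 2 `CCCCCC(CCO)n1cnc2c(Cl)nc(F)nc21` gives 8660 nM. Compound 3 `CCCCCC(CCO)n1cnc2c(Cl)ncnc21` reads > 50000 nM, which is a limit and not a number. Compound 3 thus stands at the limit of > 50000 nM in this assay, at which 1 of the 3 values shown sits. Compound 4 `CCCCCC(CCO)n1cnc2c(Cl)nc(Cl)nc21` differs from compound 3 by chloro in place of hydrogen on an aromatic carbon, with chloro in place of hydrogen on an aromatic carbon, between two ring nitrogen atoms. The nearest measured step is an at least 5.7-fold higher number from compound 2 to compound 3 (0.76 log units; beyond the scatter), where hydrogen takes the place of fluoro on an aromatic carbon. Compound 1, at 15500 nM, carries two chloro groups, as compound 4 does. A reversal of similar size is therefore expected in this assay, towards a lower number. The expected change is an at least 5.0-fold lower number from compound 3 to compound 4 (0.69 log units; beyond the scatter). Compound 4 is estimated at 10000 nM, with an expected range of 4500 nM to 22000 nM.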

Compound 4, half-maximal inhibitory concentration: 6170 nM
Compound 4: the middle estimate sits 1.6-fold (0.21 log units) above what was measured; low and high end bracket the measured number.
By their numbers in this assay, from the lowest: compounds 4, 2 and 1 (each within the scatter of the next, the first and the last beyond it). At a limit, above all of these: compound 3.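

In this assay, chloro at this position, between two ring nitrogen atoms, gives a measured value where hydrogen gives none, with an at least 8.1-fold lower number from compound 3 to compound 4 (0.90 log units; beyond the scatter). Chloro and fluoro here cannot be told apart, with a 1.4-fold lower number from compound 2 to compound 4 (0.15 log units; within the scatter). The chain matters as well: compound 4 carries a further methyl on the saturated chain, with a 2.5-fold lower number from compound 1 to compound 4 (0.40 log units; beyond the scatter).

Going by these compounds, compound 3 reads a limit and not a number, so the full size of the step from hydrogen to chloro stays open: the limit of > 50000 nM in this assay, at which 1 of the 4 values shown sits. On these data alone, whether an amine or a methoxy group at this position would keep the activity seen with chloro also stays open.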